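The source may report more compounds than this note shows. Statements on the series, on what has been measured and on what is new or still open speak of the compounds shown alone.

Three compounds have been measured in an assay on T-REx-293 cells for inhibition of potassium channel subfamily T member 1 (Homo sapiens), read by patch clamp; on this read-out higher numbers stand for weaker inhibition and lower numbers for stronger inhibition:

compound 1 `Cc1cccc(-c2noc(C(C)NC(=O)c3cc(C4CC4)nn3C)n2)c1`: 1880 nM
compound 2 `C[C@H](NC(=O)c1cc(C2CC2)nn1C)c1nc(-c2ccccc2)no1`: 11400 nM
compound 3 `Cc1cc(-c2noc([C@H](C)NC(=O)c3cc(C(F)(F)F)nn3C)n2)ccn1`: 165 nM

Of these three, compound 3 has the lowest number, and so is the strongest inhibitor of the set: compound 1 sits a good deal higher, and compound 2 higher still, both gaps well beyond the usual scatter of this assay. Compound 4 `C[C@H](NC(=O)c1cc(C(F)(F)F)nn1C)c1nc(-c2ccnc(C(F)(F)F)c2)no1` is the next compound to be tested. It is built from compound 3 by one change: trifluoromethyl in place of methyl on an aromatic carbon. Among the measured compounds shown here, no pair of measured compounds shows this same change, so there is no measured step to lean on. A change of this kind tends to move the number only modestly, and the direction is open; the expectation is for a step in this assay that is small, possibly within the scatter, with a slight lean toward a higher number. The estimated step from compound 3 to compound 4 is a 1.5-fold higher number from compound 3 to compound 4 (0.18 log units; within the scatter). Compound 4 is thus expected to give about 250 nM, with a range from 80 nM to 800 nM.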

Compound 4, half-maximal inhibitory concentration: 40 nM
Compound 4: the middle estimate sits 6.3-fold (0.80 log units) above what was measured; measured number outside the range, below it.
By their numbers in this assay, from the lowest: compound 4; then compound 3; then compound 1; then compound 2.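

In this assay, the result shows that this place on the six-membered aromatic ring, next to the ring nitrogen, responds to the group it carries: trifluoromethyl in place of methyl gives a 4.1-fold lower number from compound 3 to compound 4 (0.62 log units; beyond the scatter), a step beyond the scatter and toward stronger inhibition. The larger group, with four heavy atoms instead of one, is therefore accepted here, and this single swap is enough to change the inhibition clearly. Nothing measured here accounts for the size or direction of this step.

On these data alone, whether a chlorine atom, a nitrile or an amine at the same place would give a lower or higher number remains open. Also open, as far as these compounds go, is whether the same swap would give a similar step in another compound with an aromatic methyl, such as compound 1.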